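This account rests on a few compounds, and the source may have more. Where it says the series, first, only, none or still open, it means among the compounds named here.

In a toxicity assay on MT4 cells (Homo sapiens) for cytotoxicity, read by MTT assay (on this read-out lower numbers stand for higher toxicity in this test and higher numbers for lower toxicity in this test), three compounds built on a shared core have been measured. Compound 1 (`Cc1cc(-c2ccccc2C#N)cc(C)c1Oc1cc(N)nc(Nc2ccc(C#N)cc2)n1`) gives 25400 nM, compound 2 (`Cc1cc(-c2ccccc2)ccc1Oc1cc(N)nc(Nc2ccc(C#N)cc2)n1`) gives 20000 nM, and compound 3 (`Cc1cc(-c2ccccc2F)ccc1Oc1cc(N)nc(Nc2ccc(C#N)cc2)n1`) gives 29500 nM. These three numbers lie within the usual scatter of one another, so compound 3 cannot be ranked against the other two.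

Compound 4 (`Cc1cc(-c2ccccc2C#N)ccc1Oc1cc(N)nc(Nc2ccc(C#N)cc2)n1`) alters one group of compound 3: cyano in place of fluoro on an aromatic carbon, ortho to a large group (cyano in place of fluoro on an aromatic carbon). The nearest measured change is a 1.5-fold higher number from compound 2 to compound 3 (0.17 log units; within the scatter), with fluoro in place of hydrogen on an aromatic carbon, and it stays within the scatter. Compound 1 also carries the 2-cyanophenyl group, though its structure differs from that of compound 4 elsewhere too, and compound 1 at 25400 nM sits with the other two values. No step beyond the scatter is therefore expected, and the estimated change is a 1.2-fold lower number from compound 3 to compound 4 (0.07 log units; within the scatter). For compound 4 the estimated value is 25000 nM, with an expected range from 12000 nM to 50000 nM.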

Compound 4, half-maximal cytotoxic concentration: 28600 nM
Compound 4: middle estimate off by 1.1-fold (0.06 log units), on the low side; measured number inside the range.
By their numbers in this assay, from the lowest: compounds 2, 1, 4 and 3 (each within the scatter of the next).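

In this assay the change from 2-fluorophenyl to 2-cyanophenyl, on an aromatic carbon ortho to a large group, gives a 1.0-fold lower number from compound 3 to compound 4 (0.01 log units; within the scatter) and so adds a hydrogen-bond acceptor and one more heavy atom without moving the number beyond the scatter. Cyano in place of hydrogen at this same place gives a 1.4-fold higher number from compound 2 to compound 4 (0.16 log units; within the scatter) and also stays within the scatter, so hydrogen, fluoro and cyano cannot be told apart here. A second place behaves the same way: hydrogen in place of methyl on an aromatic carbon gives a 1.1-fold higher number from compound 1 to compound 4 (0.05 log units; within the scatter) and also stays within the scatter.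

Going by these compounds, whether an amine or a carboxylic acid at the first place would leave the number just as unmoved stays open. Nothing at hand explains why these changes make so little difference.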